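This account rests on a few compounds, and the source may have more. Where it says the series, first, only, none or still open, it means among the compounds named here.

Within the data shown here, compound 1 `CCOC(=O)C1=C(N)Oc2ccc(-c3ccc(C(C)(C)C)cc3)cc2C1C(C#N)C(=O)OCC` is one of two compounds so far measured in an assay on isolated protein for binding affinity to Bcl-2-like protein 2 (Homo sapiens), read by fluorescence polarization; on this read-out higher numbers stand for weaker inhibition and lower numbers for stronger inhibition. In this assay compound 1 gives 20300 nM, the lower of the two numbers. Among the measured compounds shown here, the only other measured compound, compound 2 `CCOC(=O)C1=C(N)Oc2ccc(C)cc2C1C(C#N)C(=O)OCC`, differs from it at one place, carrying a methyl in place of 4-(tert-butyl)phenyl on an aromatic carbon; in this assay compound 2 gives 199000 nM, and the step between them is a 9.8-fold higher number from compound 1 to compound 2 (0.99 log units; beyond the scatter).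

Compound 3 `CCOC(=O)C1=C(N)Oc2ccc(CC)cc2C1C(C#N)C(=O)OCC` has not yet been measured. It differs from compound 1 by ethyl in place of 4-(tert-butyl)phenyl on an aromatic carbon. For the measured compounds named here, the group that enters, ethyl, is a short chain without a ring, much like the methyl of compound 2, so the single step that bears on this change is the one from compound 1 to compound 2, which was modest but beyond the scatter and ran toward a weaker number. A step of similar size and in the same direction is therefore expected for compound 3, a 7.4-fold higher number from compound 1 to compound 3 (0.87 log units; beyond the scatter). Compound 3 is estimated to give 150000 nM in this assay, within a range from 55000 nM to 400000 nM.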

Compound 3, inhibition constant: 121000 nM
Beside the measured number, compound 3's estimate is 1.2-fold (0.09 log units) above it; the measured number falls inside the stated range.
By their numbers in this assay, from the lowest: compound 1; then compounds 3 and 2 (each within the scatter of the next).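

In this assay, a second short chain repeats what methyl showed: ethyl in place of 4-(tert-butyl)phenyl gives a 6.0-fold higher number from compound 1 to compound 3 (0.78 log units; beyond the scatter) and is also beyond the scatter, so the gap to compound 1 does not rest on methyl alone. Extending the short chain by one carbon does not separate the two compounds, as methyl in place of hydrogen on the saturated chain carbon gives a 1.6-fold lower number from compound 2 to compound 3 (0.22 log units; within the scatter) and the two numbers cannot be ranked. No measurement here explains why compound 1 gives the lowest number.

The compounds shown leave open whether the gap follows the aromatic ring of 4-(tert-butyl)phenyl, its tert-butyl group or simply its count of carbons, and a plain phenyl or a tert-butyl group alone on the same aromatic carbon would help to separate these. Also open, from the compounds shown here alone, is what a longer chain such as hexyl, or an amine or a carboxylic acid, would give at this place, and whether any group here could bring the number well below that of compound 1.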